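A few compounds are considered here, and "the series" means these few. Any claim that something is new, unique, unknown or untested is made for them only; others in the source may bear on it.

Measured compounds:
Compound 1 `O=c1[nH]c(=O)n(CCC(CO)CO)cc1C#Cc1cc(F)cc(F)c1` — in a functional assay on SW-620 cells (Homo sapiens) for antiproliferative activity, read by MTT assay, with a stated time of 72 h (a higher number here means a weaker inhibitor, a lower number a stronger inhibitor), compound 1 gives > 100000 nM, a limit of the assay and not a number.
Compound 2 `CCCCCC#Cc1cn(CCC(CO)CO)c(=O)[nH]c1=O` — in this assay compound 2 gives > 100000 nM, again a limit of the assay.

Compound 2 therefore stands at a limit, with no number to place it: the limit of > 100000 nM in this assay, at which 2 of the 2 values shown sit.

Compound 3 `CCCCCCCCC#Cc1cn(CCC(CO)CO)c(=O)[nH]c1=O` differs from compound 2 by propyl in place of hydrogen on a saturated chain carbon, five bonds along the chain from a triple-bonded carbon. Within the data shown here, the only measured step, a step that the two limits leave unreadable from compound 1 to compound 2, changes a different place and is itself unreadable between two limits, so no measured step bears on this extension of the chain. No step beyond the scatter is expected in this assay, and a further limit is the most likely outcome.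

For compound 3 the estimate is 100000 nM, expected between 30000 nM and 300000 nM. The step this estimate implies is a number no higher from compound 2 to compound 3 (the limit leaves the size open), an expectation only.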

Compound 3, half-maximal inhibitory concentration: > 100000 nM
Compound 3: only a limit was reported; the forecaster's own chance of this, stated with the estimate: 75%; the middle value sits exactly at the limit.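

No step can be read among compound 1, compound 2 and compound 3, as all three stand at a limit: the limit of > 100000 nM in this assay, at which 3 of the 3 values shown sit. From the compounds shown here alone, whether any group on the triple-bonded carbon gives a measurable value in this assay stays open.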